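Moving the Methyl on a Thromboxane Receptor Antagonist

The source may report more compounds than this note shows. Statements on the series, on what has been measured and on what is new or still open speak of the compounds shown alone.

Compound 1 `Cc1ccccc1Oc1ccc(C#N)cc1S(=O)(=O)NC(=O)NC(C)C` gives 6130 nM in a functional assay on HEK293 cells for antagonist activity at thromboxane A2 receptor (Homo sapiens), read by fluorescence and calcium flux; a lower number here means a stronger inhibitor, a higher number a weaker inhibitor. Compound 2 `Cc1ccccc1Nc1ccc(C#N)cc1S(=O)(=O)NC(=O)NC(C)C` gives 10100 nM in this assay and stands alongside compound 1, since the step of a 1.6-fold higher number from compound 1 to compound 2 (0.22 log units; within the scatter) lies within the scatter. Compound 3 `Cc1cccc(Nc2ccc(C#N)cc2S(=O)(=O)NC(=O)NC(C)C)c1` differs from compound 2 by 3-methylphenyl in place of 2-methylphenyl on a nitrogen on an aromatic ring. Going by the values given here, the only measured step changes the link between the two rings, not where the methyl sits, so no measured step bears on this change. For compound 3 the expected step of a 1.0-fold lower number from compound 2 to compound 3 (0.00 log units; within the scatter) is therefore none beyond the scatter. Compound 3 is estimated at 10000 nM, between 3000 nM and 33000 nM.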

Compound 3, half-maximal inhibitory concentration: 9110 nM
Compound 3: the middle estimate sits 1.1-fold (0.04 log units) above what was measured, within the range that was stated.
By their numbers in this assay, from the lowest: compounds 1, 3 and 2 (each within the scatter of the next).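

The step of a 1.1-fold lower number from compound 2 to compound 3 (0.04 log units; within the scatter) in this assay shows that 3-methylphenyl and 2-methylphenyl on this nitrogen cannot be told apart here. The step of a 1.5-fold higher number from compound 1 to compound 3 (0.17 log units; within the scatter) likewise shows no separation when (3-methylphenyl)amino stands in place of 2-methylphenoxy. No measurement is available that would explain this result. Still open, from the compounds shown here alone, is whether a different group on this phenyl ring, such as a methoxy group, a carboxylic acid or an amine, would give a step beyond the scatter.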